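Bromo for Chloro in an Amide and a Thioamide Pair

This account rests on a few compounds, and the source may have more. Where it says the series, first, only, none or still open, it means among the compounds named here.

Compound 1 `COc1ccc(Cl)cc1C(=O)Nc1ccc(Cl)cc1O`: 51300 nM
Compound 2 `COc1ccc(Cl)cc1C(=O)Nc1ccc(Br)cc1O`: 7980 nM
Compound 3 `COc1ccc(Cl)cc1C(=S)Nc1ccc(Cl)cc1O`: 4450 nM

All three were measured in a functional assay on HepG2 cells (Homo sapiens) for cytotoxicity, with a stated time of 24 h; on this read-out higher numbers stand for weaker inhibition and lower numbers for stronger inhibition. From compound 1 to compound 2 the change is bromo in place of chloro on an aromatic carbon, and it gave a 6.4-fold lower number from compound 1 to compound 2 (0.81 log units; beyond the scatter). Compound 3 has another core; how its core differs from that of compound 1 is not broken down here. Compound 4 `COc1ccc(Cl)cc1C(=S)Nc1ccc(Br)cc1O` is not yet measured. It differs from compound 3 by bromo in place of chloro on an aromatic carbon, the same change as from compound 1 to compound 2, at the same place. In this assay the step to compound 4 is expected to be a 3.7-fold lower number from compound 3 to compound 4 (0.57 log units; beyond the scatter). This expectation rests on one earlier example only, because compound 2 gives 7980 nM where compound 1 gives 51300 nM. Compound 4 is estimated at 1200 nM, likely between 400 nM and 4000 nM.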

Compound 4, half-maximal inhibitory concentration: 7600 nM
Compound 4: middle estimate off by 6.3-fold (0.80 log units), on the low side; the measured number lies above the stated range.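

In this assay, bromo in place of chloro on an aromatic carbon gives a 1.7-fold higher number from compound 3 to compound 4 (0.23 log units; within the scatter) and so makes no clear difference on this core. The same change at the same place gave clearly different results on the two cores, so its effect did not carry over from one to the other: the same change on two cores in this assay, a 6.4-fold lower number (0.81 log units; beyond the scatter) from compound 1 to compound 2 and a 1.7-fold higher number (0.23 log units; within the scatter) from compound 3 to compound 4, 11-fold (1.04 log units) apart, beyond the scatter of two such steps. Among the compounds shown here, with only one pair on each core, this warns against assuming that the lower number of compound 2 will repeat on another core, but it does not show why the two cores differ or what a third core would do.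

The compounds shown leave open whether other groups at this place, such as methyl, a nitrile or an amine, would also behave differently on the two cores. Also open, from the compounds shown here alone, is how either core would respond to a carboxylic acid in place of the hydroxy group.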